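The compounds below may be only part of what the source reports. "The series", "measured", "known", "first", "only" and "open" are said of these compounds alone.

Compound 3, `COc1cc(C(N)=O)cc2nc(NC(=O)c3ccc4ccccc4n3)n(CCCNC(=O)OCc3ccccc3)c12`, is the starting point of this account. In an assay for activation of interferon regulatory factor 3 (Homo sapiens), read by a luciferase reporter, with a stated time of 20 h (on this read-out higher numbers stand for an effect only at larger amounts of compound and lower numbers for an effect already at smaller amounts), compound 3 gives only a limit, > 100000 nM. Its nearest measured relative is compound 1, `CCCn1c(NC(=O)c2ccc3ccccc3n2)nc2cc(C(N)=O)cc(OC)c21`, which lacks the (benzyloxycarbonyl)amino group on the saturated chain carbon three bonds along the chain from an aromatic nitrogen. In this assay compound 1 likewise gives only a limit, > 100000 nM. The step that the two limits leave unreadable from compound 1 to compound 3 is therefore unreadable, because both ends sit at the limit of > 100000 nM in this assay, at which 3 of the 3 values shown sit. Within the data shown here, the third measured compound, compound 2, `CCn1nc(C)cc1C(=O)Nc1nc2cccc(OC)c2n1CCCNC(=O)OCc1ccccc1`, shares neither the amide nor the core of compound 3 in full, so no single step connects the two. In this assay compound 2 again gives only a limit, > 100000 nM.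

The compound still to be measured is compound 4, `CCn1nccc1C(=O)Nc1nc2cc(C(N)=O)cc(OC)c2n1CCCNC(=O)OCc1ccccc1`. It differs from compound 3 in a single place: 1-ethyl-1H-pyrazol-5-yl in place of quinolin-2-yl on a carbonyl carbon. Among the measured compounds shown here, no measured step touches this change, and none of the three compounds measured so far gives a number at all. For the measured compounds named here, the only guide is that every value shown sits at the limit of > 100000 nM in this assay, at which 3 of the 3 values shown sit. Compound 4 is therefore expected to remain at the same limit, with an estimated value of 100000 nM and a plausible range from 30000 nM to 300000 nM. The step of a number no higher from compound 3 to compound 4 (the limit leaves the size open) is thus expected to be none beyond the scatter, though a limit at both ends would leave it unreadable.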

Compound 4, half-maximal effective concentration: > 100000 nM
Compound 4: no number, only a limit; the forecaster's own chance of this, stated with the estimate: 85%; the middle value lies on the limit itself.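

In this assay the replacement of quinolin-2-yl by 1-ethyl-1H-pyrazol-5-yl on the carbonyl carbon, from compound 3 to compound 4, cannot be read as a step, because both compounds give only a limit: the limit of > 100000 nM in this assay, at which 4 of the 4 values shown sit.

The compounds shown leave open which change, if any, would bring a measurable half-maximal effective concentration in this assay.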